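Dropping one chloro from the aryl ring of the aminopyridine amides

The source may hold more compounds than are shown below. What is called first, only, known or untested is meant among the compounds shown, and "the series" means these compounds.

The shared core is a substituted aminopyridine carrying an aryl ring. Compound 1 `CNC(=O)c1ccc(-c2cccc(Cl)c2)c(N)n1` and compound 2 `CNC(=O)c1ccc(-c2cc(Cl)cc(Cl)c2)c(N)n1` are simple methylamides; compound 3 `Cn1nccc1C(=O)Nc1ccc(-c2cc(Cl)cc(Cl)c2Cl)c(N)n1` carries the pyrazole amide on the ring nitrogen side. In an assay on HEK293 cells for inhibition of sodium channel protein type 10 subunit alpha (Homo sapiens), read by fluorescence (on this read-out higher numbers stand for weaker inhibition and lower numbers for stronger inhibition), compound 1 reports only a limit, > 32000 nM. In this assay compound 2 likewise reports a limit, > 32000 nM. Going by the values given here, compound 3 is the sole compound with a number in this assay, 750 nM.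

The change hydrogen in place of chloro on an aromatic carbon gives the step that the two limits leave unreadable from compound 2 to compound 1; both ends sit at the limit of > 32000 nM in this assay, at which 2 of the 3 values shown sit, so its size cannot be read. The difference between the cores of compound 2 and compound 3 is not broken down here.

Compound 4 `Cn1nccc1C(=O)Nc1ccc(-c2cc(Cl)ccc2Cl)c(N)n1` arises from compound 3 by hydrogen in place of chloro on an aromatic carbon. This is the same kind of change as from compound 2 to compound 1, but the place differs: here it is also ortho to a chloro group.

For compound 4 the estimate is 2500 nM, with a range of 600 nM to 15000 nM. The estimated step is a 3.3-fold higher number from compound 3 to compound 4 (0.52 log units; beyond the scatter), resting only on compound 3 at 750 nM since the measured step that the two limits leave unreadable from compound 2 to compound 1 gives no readable size; a modest loss is expected.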

Compound 4, half-maximal inhibitory concentration: 920 nM
Beside the measured number, compound 4's estimate is 2.7-fold (0.43 log units) above it, within the range that was stated.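

On the core of compound 3, hydrogen in place of chloro gives a 1.2-fold higher number from compound 3 to compound 4 (0.09 log units; within the scatter) in this assay, so at this place, ortho to a chloro group, the step shows no change that can be told from the usual scatter. The same kind of change from compound 2 to compound 1 cannot be read, because both compounds sit at an assay limit: the limit of > 32000 nM in this assay, at which 2 of the 4 values shown sit. The series therefore holds one readable step on one core, at a place that differs from the one on the methylamide core, and this does not show whether the change carries from one core to the other.

Still open, as far as these compounds go, is how a fluoro, a methoxy or a nitrile would behave at the place the chloro left on the core of compound 3. Also open, from the compounds shown here alone, is whether either of the two remaining chloro groups on compound 4 could give way to hydrogen with as small a step.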